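This account rests on a few compounds, and the source may have more. Where it says the series, first, only, none or still open, it means among the compounds named here.

Values in a functional assay on QGY-7703 cells (Homo sapiens) for cytotoxicity, read by MTT assay, with a stated time of 24 h; a higher number here means a weaker inhibitor, a lower number a stronger inhibitor:
- compound 1 `O=C1/C(=C/c2ccncc2)CN(S(=O)(=O)c2ccccc2)C/C1=C\c1ccccc1F`: 8400 nM
- compound 2 `Cc1ccc(S(=O)(=O)N2C/C(=C\c3ccncc3)C(=O)/C(=C/c3ccccc3F)C2)cc1`: > 20000 nM, a limit

Compound 2 stands at the limit of > 20000 nM in this assay, at which 1 of the 2 values shown sits, so it has no exact number. Compound 3 `O=C1/C(=C/c2ccncc2)CN(S(=O)(=O)c2ccc([N+](=O)[O-])cc2)C/C1=C\c1ccccc1F` has nitro in place of methyl on an aromatic carbon, para to a large group (nitro in place of methyl on an aromatic carbon). Among the measured compounds shown here, the only measured step at this place is an at least 2.3-fold higher number from compound 1 to compound 2 (0.37 log units; beyond the scatter), a modest rise beyond the scatter on adding methyl. For the measured compounds named here, no measured compound carries nitro, so this step is weak guidance. Losing the methyl should bring a modest move to a lower number in this assay, and the expected step is an at least 2.0-fold lower number from compound 2 to compound 3 (0.30 log units; that floor lies within the scatter). The estimate for compound 3 is 10000 nM, with an expected range of 3500 nM to 28000 nM.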

Compound 3, half-maximal inhibitory concentration: 8800 nM
Compound 3: middle estimate off by 1.1-fold (0.06 log units), on the high side, within the range that was stated.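

In this assay, nitro in place of methyl gives an at least 2.2-fold lower number from compound 2 to compound 3 (0.35 log units; beyond the scatter), while nitro in place of hydrogen gives a 1.0-fold higher number from compound 1 to compound 3 (0.02 log units; within the scatter). The rise seen with methyl on the aromatic carbon para to a large group therefore does not extend to every added group, as nitro and hydrogen are not separated here. The size of the methyl-to-nitro step is only a floor, as compound 2 carries a limit and not a number: the limit of > 20000 nM in this assay, at which 1 of the 3 values shown sits.

Open, as far as these compounds go, is whether an amine or a carboxylic acid on this carbon would group with hydrogen and nitro or with methyl. Also open, from the compounds shown here alone, is whether a longer chain there would follow methyl.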